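The source may report more compounds than this note shows. Statements on the series, on what has been measured and on what is new or still open speak of the compounds shown alone.

Compounds measured so far in an ADME assay on NIH3T3 cells (Mus musculus) for cytotoxicity, read by MTT assay, with a stated time of 24 h; on this read-out lower numbers stand for stronger inhibition and higher numbers for weaker inhibition:

Compound 1, `COc1ccc(-c2cs/c(=N/NC(=O)CSc3nnnn3-c3ccccc3)n2-c2ccccc2)cc1`, gives 11.7 ug/mL.
Compound 2, `Cn1cnnc1SCC(=O)N/N=c1/scc(-c2ccc([N+](=O)[O-])cc2)n1-c1ccccc1`, gives 133 ug/mL.

On this read-out a lower number means a stronger effect on the cells. For the measured compounds named here, compound 2 stands at the highest of the two numbers, and the only neighbour, compound 1, lies well below it, a gap beyond the usual scatter. The two measured compounds differ in more than one place, so no single change can be read from them directly.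

Compound 3, `O=C(CSc1nnnn1-c1ccccc1)N/N=c1/scc(-c2ccc([N+](=O)[O-])cc2)n1-c1ccccc1`, has not yet been measured. It differs from compound 2 in one place: 1-phenyl-1H-tetrazol-5-yl in place of 4-methyl-4H-1,2,4-triazol-3-yl on a sulfur. The group that enters is the same one that compound 1 carries on its sulfur, while the rest of compound 3 follows compound 2.

Because compound 1, which carries the entering group, gives 11.7 ug/mL, the step of a 3.3-fold lower number from compound 2 to compound 3 (0.52 log units; beyond the scatter) is expected to go downward by a moderate amount. Compound 3 is therefore expected to give about 40 ug/mL, in a range from 12 ug/mL to 130 ug/mL.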

Compound 3, half-maximal inhibitory concentration: 14.3 ug/mL
For compound 3 the middle estimate is 2.8-fold (0.45 log units) above the measured one; the range from low to high includes it.
By their numbers in this assay, from the lowest: compounds 1 and 3 (each within the scatter of the next); then compound 2.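

In this assay, exchanging the group on the sulfur gives a 9.3-fold lower number from compound 2 to compound 3 (0.97 log units; beyond the scatter), so the group on this sulfur clearly matters here, which compound 1 and compound 2 alone could not show, as they differ in more than one place. With 1-phenyl-1H-tetrazol-5-yl on the sulfur, nitro in place of methoxy on an aromatic carbon gives a 1.2-fold higher number from compound 1 to compound 3 (0.09 log units; within the scatter), a step within the scatter, so this exchange has no readable effect in this setting. No measurement at hand bears on the reason for either result.

From the compounds shown here alone, it remains open whether the larger step comes from the tetrazole ring or from its phenyl group, and whether nitro and methoxy would also read alike with 4-methyl-4H-1,2,4-triazol-3-yl on the sulfur. The compounds shown also leave open how an amine or a carboxylic acid on that same aromatic carbon would behave, since only nitro and methoxy appear there.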